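Step from compound 2 to compound 4 in a permeability assay

The source may hold more compounds than are shown below. What is called first, only, known or untested is meant among the compounds shown, and "the series" means these compounds.

Measured compounds:
Compound 1, `O=C(/C=N/O)NCCN1CCCC1`: 1.1 10^-6 cm/s
Compound 2, `CN(C)CCCNC(=O)/C=N/O`: 1.8 10^-6 cm/s
Compound 3, `CCN(CC)CCNC(=O)/C=N/O`: 1.1 10^-6 cm/s

In an ADME assay for permeability, using PAMPA (a lower number here means that the compound crosses the layer more slowly, a higher number that the compound crosses the layer faster), compound 2 gives 1.8 10^-6 cm/s, the highest of the three numbers, yet compound 1 at 1.1 10^-6 cm/s and compound 3 at 1.1 10^-6 cm/s both sit within the scatter of it, so the three compounds are not separated by this assay.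

Compound 4, `C[N+](C)(C)CCNC(=O)/C=N/O`, has not been measured. It differs from compound 2 by one change: a group of 4 heavy atoms (3 carbon, 1 nitrogen; no ring) in place of a group of 4 heavy atoms (3 carbon, 1 nitrogen; no ring), on a saturated chain carbon, two bonds along the chain from an amide-type nitrogen. The group that leaves has no net charge; the group that enters carries a net charge.

Within the data shown here, no step between measured compounds is available to set the size of this change. The step is nonetheless expected to be downward and beyond the scatter: from the value of compound 2 at 1.8 10^-6 cm/s, compound 4 is estimated at 0.3 10^-6 cm/s, within 0.08 10^-6 cm/s to 0.9 10^-6 cm/s. That expected step is a 6.0-fold lower number from compound 2 to compound 4 (0.78 log units; beyond the scatter).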

Compound 4, apparent permeability: 1.6 10^-6 cm/s
For compound 4 the middle estimate is 5.3-fold (0.73 log units) below the measured one; the measured number lies above the stated range.
By their numbers in this assay, from the lowest: compounds 1, 3, 4 and 2 (each within the scatter of the next).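

In this assay, putting the group with net charge +1 in place of (dimethylamino)methyl, on a saturated chain carbon, two bonds along the chain from an amide-type nitrogen, gives a 1.1-fold lower number from compound 2 to compound 4 (0.05 log units; within the scatter). This first single-place step shows that, at this position, the entry of a net charge does not separate the two compounds. Nothing measured here accounts for this result. This one step leaves open whether a carboxylic acid or a primary amine at this position would also stay within the scatter.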